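Cyanophenyl for methoxyphenyl: cytotoxicity in monocytic cells

The compounds below may be only part of what the source reports. "The series", "measured", "known", "first", "only" and "open" are said of these compounds alone.

Compound 1 `COc1ccccc1NC(=O)c1c(NC(=O)C(F)(F)F)sc2c1CCCCC2` sits at a limit rather than a number: in an ADME assay on THP-1 cells (Homo sapiens) for cytotoxicity (on this read-out higher numbers stand for lower toxicity in this test and lower numbers for higher toxicity in this test), compound 1 gives > 50000 nM. Compound 2 `COc1ccc(NC(=O)c2c(NC(=O)c3ccccc3)sc3c2CCCCC3)cc1` likewise reaches only the limit, giving > 50000 nM in this assay. Compound 3 `COC(=O)Nc1sc2c(c1C(=O)Nc1ccc(OC)cc1)CCCCC2` gives > 50000 nM in this assay, again a limit. Among the measured compounds shown here, the one change between measured compounds, a step that the two limits leave unreadable from compound 2 to compound 3, therefore cannot be read, since (the limit of > 50000 nM in this assay, at which 3 of the 3 values shown sit). Compound 4 `N#Cc1ccc(NC(=O)c2c(NC(=O)C(F)(F)F)sc3c2CCCCC3)cc1` differs from compound 1 by 4-cyanophenyl in place of 2-methoxyphenyl on an amide-type nitrogen. For the measured compounds named here, no measured step bears on this change, and every value shown is a limit, so the expectation rests only on the limit of compound 1. Compound 4 is therefore expected to give 50000 nM with a range of 20000 nM to 150000 nM, most likely again a limit. The estimated step comes to a number no higher from compound 1 to compound 4 (the limit leaves the size open).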

Compound 4, half-maximal cytotoxic concentration: 9110 nM
Compound 4: middle estimate off by 5.5-fold (0.74 log units), on the high side; the measured number lies below the stated range.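

At this amide-type nitrogen the aryl group proved able to move the read-out: in this assay, 4-cyanophenyl in place of 2-methoxyphenyl gives an at least 5.4-fold lower number from compound 1 to compound 4 (0.73 log units; beyond the scatter), so the number falls towards higher toxicity in this test. Among the compounds shown here, compound 4 thus gives the only readable step, and the other steps cannot be read: the limit of > 50000 nM in this assay, at which 3 of the 4 values shown sit.

As far as these compounds go, it remains open whether the step follows from the loss of 2-methoxyphenyl or the arrival of 4-cyanophenyl. From the compounds shown here alone, how an aminophenyl or a carboxyphenyl group would read at this nitrogen also remains open.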